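Swapping fluoro for bromo on the 4-aryl series

The source may hold more compounds than are shown below. What is called first, only, known or untested is meant among the compounds shown, and "the series" means these compounds.

Measured so far in a functional assay on A549 cells (Homo sapiens) for inhibition, read by MTT assay, with a stated time of 72 h (a lower number here means a stronger inhibitor, a higher number a weaker inhibitor), with the shared core held constant:
- compound 1 `Cc1ccc(-c2nnc(SCCCN3CCN(c4nc5ccccc5s4)CC3)o2)cc1` gives 53900 nM as its value
- compound 2 `Fc1ccc(-c2nnc(SCCCN3CCN(c4nc5ccccc5s4)CC3)o2)cc1` gives 71700 nM as its value

Among the compounds with values here, compound 2 at 71700 nM sits with compound 1 at the weak end of what has been seen, and the two cannot be separated, since only two numbers exist and their gap lies within the scatter. The next compound is compound 3 `Brc1ccc(-c2nnc(SCCCN3CCN(c4nc5ccccc5s4)CC3)o2)cc1` and the change is bromo in place of fluoro on an aromatic carbon in which bromo takes the place of fluoro on an aromatic carbon, para to a large group. Within the data shown here, one measured step bears on this, namely a 1.3-fold higher number from compound 1 to compound 2 (0.12 log units; within the scatter) for fluoro in place of methyl on an aromatic carbon. Among the measured compounds shown here, that single exchange did not move the number beyond the scatter, and no bromo compound has been measured yet. The expected step of a 1.2-fold lower number from compound 2 to compound 3 (0.09 log units; within the scatter) is therefore small, with no direction firmly expected and no shift beyond the scatter anticipated. Compound 3 is expected at 58000 nM with an estimated range from 28000 nM to 110000 nM in this assay for this reading.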

Compound 3, half-maximal inhibitory concentration: 62500 nM
Compound 3: the middle estimate sits 1.1-fold (0.03 log units) below what was measured, within the range that was stated.
By their numbers in this assay, from the lowest: compounds 1, 3 and 2 (each within the scatter of the next).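

In this assay, the 4-fluorophenyl to 4-bromophenyl exchange gives a 1.1-fold lower number from compound 2 to compound 3 (0.06 log units; within the scatter), and replacing methyl with bromo at the same place gives a 1.2-fold higher number from compound 1 to compound 3 (0.06 log units; within the scatter). With a third substituent now read on this aromatic carbon, para to a large group, methyl, fluoro and bromo form a set of compounds 1, 2 and 3 in which every pairwise step lies within the scatter, so the exchanges shown give no order among these three groups. The bromo result extends the flat reading from a single exchange to all three pairs, but nothing available accounts for it.

Whether an amine, a carboxylic acid or a longer chain on this aromatic carbon would move the number beyond the scatter remains open, since the three groups shown do not define how far the reading can shift at this position. Going by these compounds, the rest of the shared core is the same in all three compounds, so the effect of a change elsewhere on the reading also remains open.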